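Thiophene in place of dimethylaminophenyl on an oxindole-triazole glycoside

The source may report more compounds than this note shows. Statements on the series, on what has been measured and on what is new or still open speak of the compounds shown alone.

Going by the values given here, compound 2 `CC(=O)OC[C@H]1O[C@@H](n2cc(CN3C(=O)/C(=C/c4ccc(N(C)C)cc4)c4ccccc43)nn2)[C@H](OC(C)=O)[C@@H](OC(C)=O)[C@@H]1OC(C)=O` gives 19400 nM in a functional assay on A549 cells (Homo sapiens) for cytotoxicity, read by sulforhodamine B assay, with a stated time of 48 h (on this read-out lower numbers stand for stronger inhibition and higher numbers for weaker inhibition), and that is the only plain number among the two values shown. Compound 1 `CC(=O)OC[C@H]1O[C@@H](n2cc(CN3C(=O)/C(=C/C=C/c4ccccc4)c4ccccc43)nn2)[C@H](OC(C)=O)[C@@H](OC(C)=O)[C@@H]1OC(C)=O` reaches only a limit of the assay, > 100000 nM in this assay. Among the compounds with values here, the one measured step, an at least 5.1-fold lower number from compound 1 to compound 2 (0.71 log units; beyond the scatter), rests on that limit of > 100000 nM in this assay, at which 1 of the 2 values shown sits, and on the single number of compound 2. Compound 3 `CC(=O)OC[C@H]1O[C@@H](n2cc(CN3C(=O)/C(=C/c4cccs4)c4ccccc43)nn2)[C@H](OC(C)=O)[C@@H](OC(C)=O)[C@@H]1OC(C)=O` differs from compound 2 by thiophen-2-yl in place of 4-(dimethylamino)phenyl on a double-bonded chain carbon bound to a double-bonded ring carbon. Within the data shown here, no measured step exchanges a single aromatic ring for a smaller hetero-aromatic ring at this position, so the step from compound 1 to compound 2 bears on it only loosely. The ring that leaves is the one whose arrival made the number fall, so in this assay compound 3 is expected to give a higher number than compound 2, estimated as a 2.3-fold higher number from compound 2 to compound 3 (0.37 log units; beyond the scatter). The estimate for compound 3 in this assay is 45000 nM, expected between 12000 nM and 150000 nM.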

Compound 3, half-maximal inhibitory concentration: 20800 nM
For compound 3 the middle estimate is 2.2-fold (0.34 log units) above the measured one; measured number inside the range.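

In this assay, exchanging the six-membered 4-(dimethylamino)phenyl for the five-membered thiophen-2-yl at this position leaves the read-out essentially unmoved, with a 1.1-fold higher number from compound 2 to compound 3 (0.03 log units; within the scatter), so neither the dimethylamino group nor the six-membered ring is needed for a number at this level. Thiophen-2-yl in place of 2-phenylethenyl gives an at least 4.8-fold lower number from compound 1 to compound 3 (0.68 log units; beyond the scatter), a step much like the one seen with 4-(dimethylamino)phenyl. That step reads only as a minimum, as compound 1 stands at a limit of the assay and not at a number: the limit of > 100000 nM in this assay, at which 1 of the 3 values shown sits.

The compounds shown leave open whether a pyridine ring, or an amine or carboxylic acid on the aromatic ring at this position, would shift the number away from those of compound 2 and compound 3. As far as these compounds go, whether the same picture holds with hydroxyl groups in place of the acetyl groups also stays open.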